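Aryl swap on the piperazine: from dimethyl to ethoxy

The source may hold more compounds than are shown below. What is called first, only, known or untested is meant among the compounds shown, and "the series" means these compounds.

Measured so far:
compound 1 `Cc1nc(-c2ccccc2)c(C(=O)N2CCN(c3cccc(Cl)c3Cl)CC2)o1` 133 nM
compound 2 `Cc1ccc(N2CCN(C(=O)c3oc(C)nc3-c3ccccc3)CC2)c(C)c1` 101 nM
compound 3 `Cc1nc(-c2ccccc2)c(C(=O)N2CCN(c3ccc(C)c(C)c3)CC2)o1` 43 nM

In a functional assay on HL-60 cells (Homo sapiens) for inhibition, read by MTT assay, with a stated time of 72 h (a higher number here means a weaker inhibitor, a lower number a stronger inhibitor), compound 3 gives the lowest of the three numbers, with a 2.3-fold lower number from compound 2 to compound 3 (0.37 log units; beyond the scatter) and a 3.1-fold lower number from compound 1 to compound 3 (0.49 log units; beyond the scatter). Compound 4 `CCOc1cccc(N2CCN(C(=O)c3oc(C)nc3-c3ccccc3)CC2)c1` differs from it by 3-ethoxyphenyl in place of 3,4-dimethylphenyl on an amine nitrogen in a ring. All three measured steps change the aryl group on this ring nitrogen: a 1.3-fold lower number from compound 1 to compound 2 (0.12 log units; within the scatter), while the two steps to compound 3 were modest. Among the compounds with values here, the ethoxy variant has no direct precedent, so only a modest step is expected in this assay, most likely a somewhat higher number than compound 3. Compound 4 is therefore estimated at 85 nM, between 30 nM and 250 nM, an expected step of a 2.0-fold higher number from compound 3 to compound 4 (0.30 log units; within the scatter).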

Compound 4, half-maximal inhibitory concentration: 151 nM
Compound 4: middle estimate off by 1.8-fold (0.25 log units), on the low side; the range from low to high includes it.
By their numbers in this assay, from the lowest: compound 3; then compounds 2, 1 and 4 (each within the scatter of the next).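

In this assay, 3-ethoxyphenyl in place of 3,4-dimethylphenyl gives a clear change on this ring nitrogen (a 3.5-fold higher number from compound 3 to compound 4 (0.55 log units; beyond the scatter)), so the aryl group here is not freely exchangeable. Against the other two aryl groups, compound 4 shows no separation (a 1.5-fold higher number from compound 2 to compound 4 (0.17 log units; within the scatter); a 1.1-fold higher number from compound 1 to compound 4 (0.06 log units; within the scatter)), which leaves compound 3 alone in having steps beyond the scatter to all the others. No available evidence accounts for this difference.

Going by these compounds, the change from compound 3 to compound 4 alters more than one feature of the aryl group, so the contribution of each remains open. A 3-methylphenyl or 3-methoxyphenyl group on the same nitrogen would help to separate them.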